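From 4-Methoxyphenyl to 3-Cyanophenyl on an Aromatic Nitrogen

A few compounds are considered here, and "the series" means these few. Any claim that something is new, unique, unknown or untested is made for them only; others in the source may bear on it.

In a functional assay on HepG2 cells (Homo sapiens) for inhibition, read by MTT assay, with a stated time of 72 h, tested at 30 uM (on this read-out lower numbers stand for less inhibition of growth and higher numbers for more inhibition of growth at the one concentration tested), compound 1 (`C=CCc1ccc(OCc2cn(-c3cccc([N+](=O)[O-])c3)nn2)c(O)c1`) gives 15.2% and compound 2 (`C=CCc1ccc(OCc2cn(-c3ccc(OC)cc3)nn2)c(O)c1`) gives 15.4%, which places the two within the scatter of each other. Compound 3 (`C=CCc1ccc(OCc2cn(-c3cccc(C#N)c3)nn2)c(O)c1`) has 3-cyanophenyl in place of 4-methoxyphenyl on an aromatic nitrogen. Among the compounds with values here, no measured step covers this change. Compound 2 differs at that same place from compound 1, and compound 1 stands at 15.2%, so no step beyond the scatter is expected in this assay. The estimated step is a number 0.4 percentage points lower from compound 2 to compound 3 (within the scatter). For compound 3 the expected value is 15%, with an estimated range of 5% to 28%.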

Compound 3, percent growth inhibition at one concentration: 2.3%
The estimate for compound 3 lay 12.7 percentage points above the measured number, outside the stated range (below it).
By their numbers in this assay, from the lowest: compound 3; then compounds 1 and 2 (each within the scatter of the next).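

In this assay the group on the aromatic nitrogen proves able to move the number, which the two earlier compounds, within the scatter of each other, did not show: 3-cyanophenyl in place of 4-methoxyphenyl gives a number 13.1 percentage points lower from compound 2 to compound 3 (beyond the scatter). Cyano in place of nitro on an aromatic carbon likewise gives a number 12.9 percentage points lower from compound 1 to compound 3 (beyond the scatter), so here the two changes at this place end in less growth inhibition. Nothing available speaks to the reason for this drop. Still open, from the compounds shown here alone, is whether an amine or a carboxylic acid in place of the cyano group would keep the number this low or bring it back up.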